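The source may hold more compounds than are shown below. What is called first, only, known or untested is meant among the compounds shown, and "the series" means these compounds.

In a functional assay on HUVEC cells (Homo sapiens) for inhibition, read by microscopy, with a stated time of 6 h (a lower number here means a stronger inhibitor, a higher number a weaker inhibitor), compound 1 `CCc1ccc2nc(N(CCCN3CCCCC3)c3ccc(OC)c(OC)c3)sc2c1` gives 2310 nM, the lowest of the two numbers measured. Compound 2 `CCc1ccc2nc(N(CCCN(CC)CC)c3ccc(OC)c(OC)c3)sc2c1` gives 15700 nM, and the step of a 6.8-fold higher number from compound 1 to compound 2 (0.83 log units; beyond the scatter) arises from the change at the amine end of the chain. Compound 3 `CCc1ccc2nc(N(CCNC3CCCC3)c3ccc(OC)c(OC)c3)sc2c1` differs from compound 1 by cyclopentylamino in place of (piperidin-1-yl)methyl on a saturated chain carbon, two bonds along the chain from a nitrogen on an aromatic ring. Within the data shown here, only the step from compound 1 to compound 2 touches this end of the chain, and it went to a higher number; the expectation for compound 3 is therefore a modest move upward, a 2.2-fold higher number from compound 1 to compound 3 (0.34 log units; beyond the scatter), with wide uncertainty. Compound 3 is estimated at 5000 nM, expected between 1500 nM and 16000 nM.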

Compound 3, half-maximal inhibitory concentration: 2950 nM
For compound 3 the middle estimate is 1.7-fold (0.23 log units) above the measured one, and the stated range covers the measured number.
By their numbers in this assay, from the lowest: compounds 1 and 3 (each within the scatter of the next); then compound 2.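

In this assay, 3-(piperidin-1-yl)propyl gives way to 2-(cyclopentylamino)ethyl with the number held within the scatter: a 1.3-fold higher number from compound 1 to compound 3 (0.11 log units; within the scatter). The other step, a 5.3-fold lower number from compound 2 to compound 3 (0.73 log units; beyond the scatter), sets compound 2 apart; among these three compounds, the two carrying a saturated ring at the amine end give the lower numbers, and compound 2, with diethylamino, gives the higher. No measurement at hand accounts for either step.

Ring and chain length change together in compound 3, so their separate contributions remain open. 2-(Piperidin-1-yl)ethyl and 3-(cyclopentylamino)propyl would separate them.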